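The source may hold more compounds than are shown below. What is called first, only, known or untested is meant among the compounds shown, and "the series" means these compounds.

In a functional assay on CAKI-1 cells (Homo sapiens) for cytotoxicity, read by sulforhodamine B assay, with a stated time of 48 h (a lower number here means a stronger inhibitor of growth, a higher number a weaker inhibitor of growth), three compounds built on one shared core have been measured. Compound 1 `ClCc1ccccc1Cn1cnc2c(Cl)nc(Cl)nc21` gives 890 nM in this assay. Compound 2 `ClCc1cccc(Cn2cnc3c(Cl)ncnc32)c1` gives 2950 nM. Compound 3 `ClCc1ccccc1Cn1cnc2ncnc(Cl)c21` gives 4160 nM, the highest of the three numbers; its gap to compound 2 lies within the scatter, whereas compound 1 stands beyond the scatter with the lower number.

Compound 4 `ClCc1ccccc1Cn1cnc2nc(Cl)nc(Cl)c21` has not yet been measured. It differs from compound 3 by chloro in place of hydrogen on an aromatic carbon, the chloro entering on an aromatic carbon of a six-membered aromatic ring with two nitrogen, between two ring nitrogen atoms, meta to a chloro group. Going by the values given here, no measured pair differs in only one place, so the size of such a step is not known from these data. Among the compounds with values here, the only compound carrying two chloro groups on the core, compound 1, gives 890 nM, a lower number than compound 3. On that slender basis a move toward a lower number is expected, though a step that stays within the scatter is also possible. Compound 4 is expected to give about 1500 nM, within a range from 500 nM to 5000 nM. The expected step is a 2.8-fold lower number from compound 3 to compound 4 (0.44 log units; beyond the scatter).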

Compound 4, concentration for total growth inhibition: 34700 nM
Beside the measured number, compound 4's estimate is 23-fold (1.36 log units) below it, and the stated range ends below it.
By their numbers in this assay, from the lowest: compound 1; then compounds 2 and 3 (each within the scatter of the next); then compound 4.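

In this assay, going by these compounds alone, the chloro entering on the aromatic carbon between two ring nitrogen atoms gives an 8.3-fold higher number from compound 3 to compound 4 (0.92 log units; beyond the scatter), the first step in this set that can be read at a single place. At this position on the shared core, chloro in place of hydrogen therefore goes with a weaker inhibitor of growth, a direction that compounds 1, 2 and 3 could not show, since no two of them differ in only one place. The data offer no measured explanation for this step.

On these data alone, whether this step belongs to chloro in particular or would also follow from another group on this carbon, such as an amine, a methoxy group or a fluoro group, stays open. Also open, as far as these compounds go, is whether the same change would have a step of similar size with the chloromethyl group placed as in compound 2.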